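Swapping Fluoro for Chloro on the Phenyl Ring

The source may hold more compounds than are shown below. What is called first, only, known or untested is meant among the compounds shown, and "the series" means these compounds.

Measured so far:
- compound 1 `c1ccc(-c2nc3ccc(N4CCCCC4)nc3o2)cc1`: 86.8%
- compound 2 `Fc1cccc(-c2nc3ccc(N4CCCCC4)nc3o2)c1`: 89.7%

Among the measured compounds shown here, in an assay on isolated protein for inhibition of Amine oxidase [flavin-containing] B (Homo sapiens), read by fluorescence, with a stated time of 1 h, tested at 10 uM (a lower number here means less inhibition, a higher number more inhibition at the concentration tested (going by the name of the read-out)), compound 2 gives 89.7%, the higher of the two numbers measured so far, though its nearest neighbour compound 1 gives 86.8%, and the gap between the two lies within the usual scatter of this assay. For the measured compounds named here, the only measured step, a number 2.9 percentage points higher from compound 1 to compound 2 (within the scatter), came from putting fluoro in place of hydrogen on an aromatic carbon of the shared core, and it did not move the number beyond the scatter.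

Compound 3 `Clc1cccc(-c2nc3ccc(N4CCCCC4)nc3o2)c1` has not yet been measured. It differs from compound 2 by chloro in place of fluoro on an aromatic carbon. Going by the values given here, no measured step covers a chloro entering in place of a fluoro, so the only guide is that the same ring position accepted fluoro without a change beyond the scatter. The expectation for compound 3 is therefore a step of about a number 1.7 percentage points lower from compound 2 to compound 3 (within the scatter) in this assay, that is, no movement beyond the scatter. Compound 3 is estimated to give about 88%, within a range from 74% to 97%.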

Compound 3, a percentage reported as inhibition, at one concentration (the size of the read-out at that concentration, not a potency): 91.7%
Compound 3: middle estimate off by 3.7 percentage points, on the low side, and the stated range covers the measured number.
By their numbers in this assay, from the lowest: compounds 1, 2 and 3 (each within the scatter of the next).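

Chloro at this place, on an aromatic carbon of a six-membered aromatic ring of carbon only and meta to a large group, behaves like fluoro in this assay: the change from 3-fluorophenyl to 3-chlorophenyl gives a number 2 percentage points higher from compound 2 to compound 3 (within the scatter) and so does not separate the two halogens. Set against hydrogen on the same carbon, chloro gives a number 4.9 percentage points higher from compound 1 to compound 3 (within the scatter), so with two different halogens now in hand, this carbon accepts either one without any step leaving the scatter. No measurement shown here offers an explanation for this flat result.

On these data alone, what remains open is whether this position can respond at all, since hydrogen, fluoro and chloro give readings that cannot be told apart, and a single test concentration gives the size of the inhibition and not a potency. A methoxy group, a nitrile, an amine or a carboxylic acid on the same carbon would show whether the number can leave the scatter, and whether it then moves up or down.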